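Working notes: from compound 2 to compound 4

This account rests on a few compounds, and the source may have more. Where it says the series, first, only, none or still open, it means among the compounds named here.

In a physicochemical assay, with a stated time of 30 min (on this read-out higher numbers stand for weaker inhibition and lower numbers for stronger inhibition), compound 1 `COc1cc2c(cc1OC)C(=O)C(C(=O)Nc1ccccc1)C2` gives 61.3 ug/mL, compound 2 `COc1cc2c(cc1OC)C(=O)C(C(=O)Nc1ccc(F)cc1)C2` gives 55 ug/mL and compound 3 `CCOc1cccc(NC(=O)C2Cc3cc(OC)c(OC)cc3C2=O)c1` gives 44.9 ug/mL. Compound 2 sits within the scatter of both other compounds, so no order can be read among them. The next structure is compound 4 `COc1ccccc1NC(=O)C1Cc2cc(OC)c(OC)cc2C1=O`, described by this change: 2-methoxyphenyl in place of 4-fluorophenyl on an amide-type nitrogen. Within the data shown here, two measured steps bear on it, both made on the aromatic ring of the group on the amide-type nitrogen. Fluoro in place of hydrogen gave a 1.1-fold lower number from compound 1 to compound 2 (0.05 log units; within the scatter), and ethoxy in place of hydrogen gave a 1.4-fold lower number from compound 1 to compound 3 (0.14 log units; within the scatter). Neither step leaves the scatter, and the ethoxy step is the nearer guide, since ethoxy and methoxy are both ether groups. Among the measured compounds shown here, no measured compound carries the 2-methoxyphenyl group, so the range stays wide. In this assay no shift beyond the scatter is expected, and the estimated step is a 1.1-fold lower number from compound 2 to compound 4 (0.06 log units; within the scatter). Compound 4 is estimated at 48 ug/mL, with an expected range of 27 ug/mL to 85 ug/mL.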

Compound 4, half-maximal inhibitory concentration: 45.8 ug/mL
The estimate for compound 4 lay 1.0-fold (0.02 log units) above the measured number; measured number inside the range.
By their numbers in this assay, from the lowest: compounds 3, 4, 2 and 1 (each within the scatter of the next).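

In this assay, among these compounds, the step of a 1.2-fold lower number from compound 2 to compound 4 (0.08 log units; within the scatter) exchanges one substituted aromatic group for another on the amide-type nitrogen, whereas the earlier steps each replaced hydrogen, and it too stays within the scatter. A methoxy group on the aromatic ring, where compound 1 carries hydrogen, gives a 1.3-fold lower number from compound 1 to compound 4 (0.13 log units; within the scatter) and adds a third group at this part of the series without any step leaving the scatter, so compound 1, compound 2, compound 3 and compound 4 cannot be ordered. Nothing available explains these small steps.

The compounds shown leave open whether an amine or a carboxylic acid on this aromatic ring would move the number beyond the scatter. They also leave open whether a longer chain, such as butoxy, or a saturated ring in place of the aromatic group would do so.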